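Trimming a tert-butyl to isopropyl on an aryl enone acid

The compounds below may be only part of what the source reports. "The series", "measured", "known", "first", "only" and "open" are said of these compounds alone.

Compound 1 `CC(C)c1ccc(C(C)C)c(C(=O)/C=C/C(=O)O)c1`: 4750 nM
Compound 2 `CC(C)(C)c1ccc(C(=O)/C=C/C(=O)O)cc1`: 5100 nM
Compound 3 `COc1ccc(C(=O)/C=C/C(=O)O)c(OC)c1OC`: 96200 nM

Three aryl enone acids were measured in a functional assay on HeLa cells (Homo sapiens) for inhibition, read by MTT assay, with a stated time of 72 h; a lower number here means a stronger inhibitor, a higher number a weaker inhibitor. Compound 2 gives 5100 nM, the second highest of the three numbers. Its nearest neighbour is compound 1, which gives 4750 nM, a gap within the scatter, so the two cannot be ordered. Compound 3 gives 96200 nM, a much higher number, beyond the scatter.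

The step to the unmeasured compound 4 `CC(C)c1ccc(C(=O)/C=C/C(=O)O)cc1` is a small one at the saturated chain carbon: hydrogen in place of methyl on a saturated chain carbon bound to an aromatic carbon and two saturated chain carbons. Within the data shown here, no measured pair shows this exact change, so nothing in the data sets its size. Compound 1, which carries isopropyl groups and gives 4750 nM, sits within the scatter of compound 2, which suggests that such alkyl groups on this core land in one narrow band. The step is therefore expected to be small, with no direction beyond the scatter, as a 1.1-fold higher number from compound 2 to compound 4 (0.03 log units; within the scatter). Compound 4 is expected to give 5500 nM, in the range 2500 nM to 12000 nM.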

Compound 4, half-maximal inhibitory concentration: 4900 nM
Compound 4: the middle estimate sits 1.1-fold (0.05 log units) above what was measured; the measured number falls inside the stated range.
By their numbers in this assay, from the lowest: compounds 1, 4 and 2 (each within the scatter of the next); then compound 3.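

In this assay, among these compounds, the trim of tert-butyl to isopropyl reads as a 1.0-fold lower number from compound 2 to compound 4 (0.02 log units; within the scatter) and forms the first measured pair that differs in one place. Hydrogen in place of methyl on this saturated chain carbon, bound to an aromatic carbon and two saturated chain carbons, thus leaves the number within the scatter, so this one methyl can go without a measurable step in this assay. Nothing measured here gives a reason for this result.

The compounds shown leave open whether larger changes at this place would also pass without a step, such as an ethyl group, a methyl group alone, a hydroxyl or an amine in place of the isopropyl. This single pair also cannot say whether the same trim would read alike on a core that carries a second alkyl group.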